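From open-chain amine to 3-aminopiperidin-1-yl in compound 4

A few compounds are considered here, and "the series" means these few. Any claim that something is new, unique, unknown or untested is made for them only; others in the source may bear on it.

In an ADME assay on liver for metabolic stability, with Liver microsome (Homo sapiens) as the target, using microsomes (on this read-out lower numbers stand for slow clearance and higher numbers for fast clearance), compound 1 `CC(=O)Nc1cccc(Nc2cc(NC3CC3)n3ncc(C#N)c3n2)c1` gives 20 mL.min-1.g-1. Compound 2 `CCN(CCN)c1ccc(Nc2cc(NC3CC3)n3ncc(C#N)c3n2)cc1NC(C)=O` gives 5 mL.min-1.g-1, the lower of the two true numbers in this set. Compound 3 `CC(=O)Nc1cc(Nc2cc(NC3CC3)n3ncc(C#N)c3n2)ccc1N1CC[C@H](N)C1` reads < 3 mL.min-1.g-1, and this is a limit of the assay, not a number.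

Adding the open-chain group to the shared core gave a 4.0-fold lower number from compound 1 to compound 2 (0.60 log units; beyond the scatter). Adding 3-aminopyrrolidin-1-yl gave an at least 6.6-fold lower number from compound 1 to compound 3 (0.82 log units; beyond the scatter). Exchanging the open chain for that ring gave an at least 1.6-fold lower number from compound 2 to compound 3 (0.22 log units; that floor lies within the scatter), and this floor lies within the scatter, so the data do not separate the two compounds.

Compound 4 `CC(=O)Nc1cc(Nc2cc(NC3CC3)n3ncc(C#N)c3n2)ccc1N1CCC[C@@H](N)C1` is the next case, with the change (a group of 7 heavy atoms (5 carbon, 2 nitrogen; one six-membered non-aromatic ring with 1 hetero atom) in place of a group of 6 heavy atoms (4 carbon, 2 nitrogen; no ring), on an aromatic carbon). Here 3-aminopiperidin-1-yl takes the place of the open chain on an aromatic carbon, ortho to an acetamido group. The nearest measured precedent is the other exchange of this chain for a ring, an at least 1.6-fold lower number from compound 2 to compound 3 (0.22 log units; that floor lies within the scatter), which shows no step beyond the scatter. The larger steps seen on adding either group to compound 1 do not apply, since compound 2 already carries a group at that place.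

The step expected is a 1.3-fold lower number from compound 2 to compound 4 (0.10 log units; within the scatter), an estimate that stays within the scatter. For compound 4 the estimate is 4 mL.min-1.g-1, with an expected range of 2 mL.min-1.g-1 to 9 mL.min-1.g-1.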

Compound 4, intrinsic clearance in microsomes: < 3 mL.min-1.g-1
Compound 4 ended at the assay's limit; the forecaster's own chance of this, stated with the estimate: 35%; middle value at least 1.3-fold (0.12 log units) away from the limit.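

Placing 3-aminopiperidin-1-yl on the shared core gave an at least 6.6-fold lower number from compound 1 to compound 4 (0.82 log units; beyond the scatter) in this assay, so a six-membered ring amine at this position, ortho to an acetamido group, now stands with the five-membered ring of compound 3 as a second ring that ends at a limit of the assay rather than at a number. Exchanging the open chain for this ring gave an at least 1.6-fold lower number from compound 2 to compound 4 (0.22 log units; that floor lies within the scatter), so this second exchange, like the first, does not separate the ring from the open chain of compound 2. The step between the two rings cannot be read because compound 3 and compound 4 both sit at a limit, with no number for either: the limit of < 3 mL.min-1.g-1 in this assay, at which 2 of the 4 values shown sit.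

Every group shown at this position carries an amine, so these compounds do not tell whether that amine matters to the read-out; a plain piperidin-1-yl or a 3-hydroxypiperidin-1-yl group would bear on this. Going by these compounds, how far compound 3 and compound 4 lie past the limit, and whether ring size matters there, also stays open.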